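Swapping a Cyclohexyl for a 2-Fluorophenyl Group

The source may hold more compounds than are shown below. What is called first, only, known or untested is meant among the compounds shown, and "the series" means these compounds.

Compound 1, `C[C@]1(CN2CCc3nc(-c4ccc(F)cc4)sc3C2)Cn2cc([N+](=O)[O-])nc2O1`: > 32 ug/mL
Compound 2, `C[C@]1(CN2CCn3nc(-c4ccc(F)c(F)c4)nc3C2)Cn2cc([N+](=O)[O-])nc2O1`: "not determined" (no result reported)
Compound 3, `C[C@]1(CN2CCc3nc(C4CCCCC4)ccc3C2)Cn2cc([N+](=O)[O-])nc2O1`: "not determined" (no result reported)

In an ADME assay on Vero cells (Chlorocebus sabaeus) for cytotoxicity, read by MTT assay, with a stated time of 72 h (a lower number here means that less compound is tolerated, a higher number that more compound is tolerated), compound 1 reaches only a limit of the assay, not a number. Compound 2 has no result in this assay. Compound 3 likewise has no result in this assay, so it stands nowhere on the numbers shown; the only information is that one of the three entries sits at the limit of > 32 ug/mL in this assay, at which 1 of the 3 values shown sits. Compound 4, `C[C@]1(CN2CCc3nc(-c4ccccc4F)ccc3C2)Cn2cc([N+](=O)[O-])nc2O1`, differs from compound 3 by 2-fluorophenyl in place of cyclohexyl on an aromatic carbon. Among the measured compounds shown here, no measured step exists, so no direction or size can be read from the data. Compound 4 is expected to be tolerated at a similar level to compound 1 at the limit of > 32 ug/mL in this assay, at which 1 of the 3 values shown sits, roughly 32 ug/mL, within 12 ug/mL to 64 ug/mL.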

Compound 4, half-maximal cytotoxic concentration: > 32 ug/mL
Compound 4: a limit, no number; the forecaster's own chance of this, stated with the estimate: 60%; the middle value lies on the limit itself.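

No step can be read from compound 3 to compound 4, whose value is a limit and not a number: the limit of > 32 ug/mL in this assay, at which 2 of the 4 values shown sit. On these data alone, whether 2-fluorophenyl in place of cyclohexyl changes how much compound the cells tolerate stays open.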